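Swapping bromo for chloro on a weak growth inhibitor

A few compounds are considered here, and "the series" means these few. Any claim that something is new, unique, unknown or untested is made for them only; others in the source may bear on it.

Within the data shown here, in a functional assay on HT-29 cells (Homo sapiens) (a higher number here means a weaker inhibitor of growth, a lower number a stronger inhibitor of growth), compound 3 (`O=S(=O)(/C=C/c1ccc(Br)cc1)Cc1ccc(Nc2ncnc3ccc(Br)cc23)cc1`) gives 10000 nM as the lowest of the three numbers so far. Compound 2 (`O=S(=O)(/C=C/c1ccc(Cl)c(Cl)c1)Cc1ccc(Nc2ncnc3ccc(Br)cc23)cc1`) stands at 27000 nM and compound 1 (`O=S(=O)(/C=C/c1ccc(Cl)cc1)Cc1ccc(Nc2ncnc3ccccc23)cc1`) at 73000 nM on the higher side.

Compound 4 (`O=S(=O)(/C=C/c1ccc(Cl)cc1)Cc1ccc(Nc2ncnc3ccc(Br)cc23)cc1`) is compound 3 with chloro in place of bromo on an aromatic carbon, para to a large group (chloro in place of bromo on an aromatic carbon) and nothing else changed. The closest measured step is a 2.7-fold lower number from compound 2 to compound 3 (0.43 log units; beyond the scatter) and counts as modest, yet it replaces 3,4-dichlorophenyl with 4-bromophenyl and so does not separate bromo from chloro. The 4-chlorophenyl of compound 4 also appears on compound 1 at 73000 nM but without the bromo on the core, so that number cannot isolate chloro either. No direct comparison of bromo and chloro has been measured here, so a swap of one atom is expected to move the number less than that modest step. Any lean is upward, as the chlorine-bearing compound 2 at 27000 nM also sits higher than compound 3. The expected change is a 1.5-fold higher number from compound 3 to compound 4 (0.18 log units; within the scatter) in this assay as a slight rise within the scatter. For compound 4 the estimated value is 15000 nM with an expected range from 6000 nM to 35000 nM in this measurement.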

Compound 4, concentration for 50% growth inhibition: > 100000 nM
Compound 4 was reported as a limit; the forecaster's own chance of this, stated with the estimate: 5%; middle value at least 6.6-fold (0.82 log units) from the limit.
By their numbers in this assay, from the lowest: compound 3; then compound 2; then compound 1. At a limit, above all of these: compound 4.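

In this assay compound 4 gives > 100000 nM, which is a limit of the assay and not a number. Chloro in place of bromo on an aromatic carbon, para to a large group, is on its own enough for an at least 10-fold higher number from compound 3 to compound 4 (1.00 log units; beyond the scatter), so this one-atom change at this position can matter far more than the earlier compounds could reveal, and its full size stays unknown: the limit of > 100000 nM in this assay, at which 1 of the 4 values shown sits. Hydrogen in place of chloro on an aromatic carbon also counts, with an at least 3.7-fold higher number from compound 2 to compound 4 (0.56 log units; beyond the scatter), so on the shared core carrying bromo, the 4-chlorophenyl compound sits above both the 4-bromophenyl and the 3,4-dichlorophenyl compounds.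

What bromo on the core contributes cannot be settled, since an at least 1.3-fold higher number from compound 1 to compound 4 (0.13 log units; that floor lies within the scatter) gives only a floor and both of those compounds have numbers too weak to separate with confidence. On these data alone, it also remains open how a fluoro, a methyl or a methoxy group on that same aromatic carbon would compare with bromo, and whether the sharp rise with chloro is a peculiarity of this one series.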